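Amide nitrogen substituent changes in a weakly cytotoxic series

The compounds below may be only part of what the source reports. "The series", "measured", "known", "first", "only" and "open" are said of these compounds alone.

Compound 1 `COCOc1cc(/C=C/C(=O)OCC(=O)Nc2ccc(OC)cc2)ccc1OCc1ccccc1` gives 155000 nM in a functional assay on HeLa cells (Homo sapiens) for cytotoxicity, read by MTT assay, with a stated time of 72 h; a lower number here means a stronger inhibitor, a higher number a weaker inhibitor.
Compound 2 `COCOc1cc(/C=C/C(=O)OCC(=O)Nc2ccc(Cl)cc2)ccc1OCc1ccccc1` reaches only the limit > 200000 nM in this assay.
Compound 3 `COCOc1cc(/C=C/C(=O)OCC(=O)NN2CCOCC2)ccc1OCc1ccccc1` likewise reaches only the limit > 200000 nM in this assay.

Within the data shown here, compound 3 therefore stands at the limit (the limit of > 200000 nM in this assay, at which 2 of the 3 values shown sit), with no number of its own; compound 1 is the only compound with a number, and the step of an at least 1.2-fold higher number from compound 1 to compound 3 (0.11 log units; that floor lies within the scatter) is bounded only at its floor. The change to compound 4 `COCOc1cc(/C=C/C(=O)OCC(=O)Nc2nccs2)ccc1OCc1ccccc1` is 1,3-thiazol-2-yl in place of morpholin-4-yl on an amide-type nitrogen. Among the measured compounds shown here, the steps that bear on it are an at least 1.2-fold higher number from compound 1 to compound 3 (0.11 log units; that floor lies within the scatter) and a step that the two limits leave unreadable from compound 2 to compound 3, both swaps at the amide-type nitrogen read against the limit; neither gives a size. Compound 4 is expected near the limit again, an estimated 200000 nM (range 90000 nM to 450000 nM). The expected step of a number no higher from compound 3 to compound 4 (the limit leaves the size open) is not readable beyond the scatter.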

Compound 4, half-maximal inhibitory concentration: > 200000 nM
Compound 4: no number, only a limit; the forecaster's own chance of this, stated with the estimate: 60%; the middle value lies on the limit itself.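

Compound 4 gives only a limit, > 200000 nM, in this assay, so 1,3-thiazol-2-yl on the amide-type nitrogen joins morpholin-4-yl and 4-chlorophenyl without a number of its own. Among these compounds, the only readable new step is an at least 1.2-fold higher number from compound 1 to compound 4 (0.11 log units; that floor lies within the scatter), and the steps between compounds at the limit cannot be read. The 4-methoxyphenyl of compound 1 remains the only group here with a number, and the series gathers at one point: the limit of > 200000 nM in this assay, at which 3 of the 4 values shown sit.

Going by these compounds, whether a 4-hydroxyphenyl or pyridin-2-yl group on this nitrogen would give a number stays open. So does how far compound 2, compound 3 and compound 4 lie from one another.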